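The source may report more compounds than this note shows. Statements on the series, on what has been measured and on what is new or still open speak of the compounds shown alone.

Compound 1 `O=C(NC(=S)NNc1ncnc2ccccc12)c1ccccc1` and compound 2 `COc1cc2ncnc(NNC(=S)NC(=O)c3ccccc3)c2cc1OC` are built on different cores; the difference between the two cores is not broken down here. In a functional assay on MCF7 cells (Homo sapiens) for cytotoxicity, read by MTT assay, with a stated time of 72 h (on this read-out lower numbers stand for stronger inhibition and higher numbers for weaker inhibition), compound 1 gives 5960 nM, and in this assay compound 2 gives 6990 nM. Compound 3 `Cc1ccccc1C(=O)NC(=S)NNc1ncnc2ccccc12` differs from compound 1 by one change, (methyl in place of hydrogen on an aromatic carbon), and in this assay compound 3 gives 16500 nM; that change made a 2.8-fold higher number from compound 1 to compound 3 (0.44 log units; beyond the scatter).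

Compound 4 `COc1cc2ncnc(NNC(=S)NC(=O)c3ccccc3C)c2cc1OC` is not yet measured. It differs from compound 2 by methyl in place of hydrogen on an aromatic carbon, and the place of the change is described in the same words for both pairs, so this is the same change, now made on the core of compound 2. Among the measured compounds shown here, the expectation for compound 4 rests on the one earlier example: because a 2.8-fold higher number from compound 1 to compound 3 (0.44 log units; beyond the scatter) was a modest step beyond the scatter, the step from compound 2 to compound 4 in this assay is expected to be of similar size, a 2.6-fold higher number from compound 2 to compound 4 (0.41 log units; beyond the scatter). Compound 4 is therefore estimated at 18000 nM, with a range from 9000 nM to 40000 nM.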

Compound 4, half-maximal inhibitory concentration: 19300 nM
Beside the measured number, compound 4's estimate is 1.1-fold (0.03 log units) below it; the measured number falls inside the stated range.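

In this assay, turning phenyl into 2-methylphenyl on the core of compound 2 gave a 2.8-fold higher number from compound 2 to compound 4 (0.44 log units; beyond the scatter) and so weaker inhibition, the same direction as on the core of compound 1. The two steps match in size, so in this pair of cores the effect of the methyl carries over without visible influence from the difference between the cores: the same change on two cores in this assay, a 2.8-fold higher number (0.44 log units; beyond the scatter) from compound 1 to compound 3 and a 2.8-fold higher number (0.44 log units; beyond the scatter) from compound 2 to compound 4, 1.0-fold (0.00 log units) apart, within the scatter of two such steps. Among the compounds shown here, this rests on only two pairs in one cell-based assay, so it does not show that the step would hold on any other core, and it does not explain why the methyl raises the number.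

The compounds shown leave open whether the loss belongs to methyl in particular or would also follow from another group in the same place, such as a chlorine atom, a methoxy group or a longer chain like ethyl. They also leave open what a methyl elsewhere on that ring would do, and whether any such change could lower the number rather than raise it.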